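This account rests on a few compounds, and the source may have more. Where it says the series, first, only, none or still open, it means among the compounds named here.

Measured compounds:
compound 1, `CC(NC(=O)c1nc(-c2nccs2)sc1C1CC1)c1ccc(C(=O)NO)cc1`, 41.7 nM in an assay on cells for inhibition of protein deacetylase HDAC6 (Homo sapiens), read by fluorescence, with a stated time of 24 h; on this read-out higher numbers stand for weaker inhibition and lower numbers for stronger inhibition
compound 2, `CC(C)(NC(=O)c1nc(-c2nccs2)sc1C1CC1)c1ccc(C(=O)NO)cc1`, 148 nM in this assay

Compound 1 stands with the lower of the two numbers in this assay; its nearest neighbour is compound 2, and the step of a 3.5-fold higher number from compound 1 to compound 2 (0.55 log units; beyond the scatter) lies beyond the scatter.

Compound 3, `C[C@@H](NC(=O)c1nc(-c2nccs2)sc1C1CC1)c1ccc(C(=O)NO)cc1`, is not yet measured in this assay. Relative to compound 1 the change is the two compounds have the same atoms and bonds; at least one stereo element is drawn with a configuration in one of them and without one in the other: 1 of 1 stereo elements differ; a stereocentre at a saturated chain carbon is drawn without a configuration in compound 1 and R in compound 3: the atoms and bonds are the same, and only the drawn configuration at the saturated chain carbon differs, compound 1 being drawn without one and compound 3 as R.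

Among the compounds with values here, neither measured compound speaks to this change; the one measured step, from compound 1 to compound 2, concerns a methyl entering on that carbon, not its configuration. Compound 1 can be read as the mixture of both configurations, so compound 3 may sit either side of it. Compound 3 is therefore expected near compound 1, with the step of a 1.2-fold lower number from compound 1 to compound 3 (0.08 log units; within the scatter), and the estimate for compound 3 in this assay is 35 nM, within 12 nM to 120 nM.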

Compound 3, half-maximal inhibitory concentration: 211 nM
Beside the measured number, compound 3's estimate is 6.0-fold (0.78 log units) below it, and the stated range ends below it.
By their numbers in this assay, from the lowest: compound 1; then compounds 2 and 3 (each within the scatter of the next).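

In this assay, the configuration at the saturated chain carbon proves to matter, which the methyl step from the earlier pair could not show: a 5.1-fold higher number from compound 1 to compound 3 (0.70 log units; beyond the scatter). The only difference the two drawings carry at this place is stated as follows: the fact that one of compounds 1 and 3 is drawn with a defined configuration and the other without, at the place where they differ Should compound 1 be a mixture of both configurations, the R form in compound 3 would not be the one carrying the stronger inhibition, and the S form would be expected to give a lower number than compound 1, though nothing shown confirms this.

The compounds shown leave open how the S form alone would read and what configurations compound 1 actually contains. They also leave open how an ethyl group or a hydroxymethyl group in place of the methyl on that carbon would read in either configuration.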